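Adding bromo to compound 3

The source may hold more compounds than are shown below. What is called first, only, known or untested is meant among the compounds shown, and "the series" means these compounds.

Of the compounds shown here, three have been read in a functional assay on HO8910 cells (Homo sapiens) for inhibition, read by MTT assay, with a stated time of 24 h, tested at 10 ug/mL; on this read-out lower numbers stand for less inhibition of growth and higher numbers for more inhibition of growth at the one concentration tested. There, compound 1 (`O=C(CCCCC1CCSS1)Nc1ccccn1`) gives "not active" (no number reported), and compound 2 (`O=C(CCCCC1CCSS1)Nc1ccc(Br)cn1`) gives 29.6%. Compound 3 (`O=C(CCCCC(S)CCS)Nc1ccccn1`) gives "not active" (no number reported), so, like compound 1, it has no single number, and only compound 2 carries a figure. Compound 4 (`O=C(CCCCC(S)CCS)Nc1ccc(Br)cn1`) is compound 3 with one change: bromo in place of hydrogen on an aromatic carbon. A modest upward step beyond the scatter is expected in this assay, resting solely on compound 2 at 29.6%, which also carries bromo. This is thin support, and a reading without a number remains possible. Compound 4 is estimated at 25%, with an expected range of 8% to 45%.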

Compound 4, percent growth inhibition at one concentration: 29.4%
For compound 4 the middle estimate is 4.4 percentage points below the measured one, within the range that was stated.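

In this assay compound 3 gives "not active" (no number reported) and compound 4 gives 29.4% with bromo on the aromatic carbon two atoms from the ring nitrogen, so bromo at this place goes with a number on the open chain too, as it does on the ring-bearing compound 2. With bromo present, a number 0.2 percentage points lower from compound 2 to compound 4 (within the scatter) puts the ring-free side group level with the ring-bearing one. Nothing available gives a cause for this.

From the compounds shown here alone, whether chloro, an amine or a carboxylic acid at this place would also give a number remains open. So does the reading of a longer chain.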